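The source may hold more compounds than are shown below. What is called first, only, known or untested is meant among the compounds shown, and "the series" means these compounds.

The measured compounds:
compound 1, `CCC1(CCCCN2CCN(c3ccccc3)CC2)C(=O)Nc2ccccc21`: 2.07 nM
compound 2, `CCC1(CCCCN2CCN(c3ccccc3OC)CC2)C(=O)Nc2ccccc21`: 5.38 nM
compound 3, `CCC1(CCCCN2CCN(c3ccc(C)c(Cl)c3)CC2)C(=O)Nc2ccccc21`: 0.66 nM

In an assay on CHO cells for displacement of a labelled ligand from 5-hydroxytryptamine receptor 7 (Homo sapiens) (a lower number here means a stronger inhibitor, a higher number a weaker inhibitor), compound 2 stands with the highest of the three numbers; the two steps that place it are a 2.6-fold higher number from compound 1 to compound 2 (0.41 log units; beyond the scatter) and an 8.2-fold lower number from compound 2 to compound 3 (0.91 log units; beyond the scatter). Compound 4, `CCC1(CCCCN2CCN(c3ccccc3OC)CC2)C(=O)N(Cc2ccccc2)c2ccccc21`, differs from compound 2 by benzyl in place of hydrogen on an amide-type nitrogen in a ring. None of the three measured steps touches that nitrogen: a 3.1-fold lower number from compound 1 to compound 3 (0.50 log units; beyond the scatter) and the other two all concern the aryl group on the piperazine nitrogen, so nothing here bears directly on the change. A modest step in either direction is expected, with a weaker number somewhat more likely. Compound 4 is therefore expected to give 15 nM, between 3 nM and 80 nM. This estimate means a 2.8-fold higher number from compound 2 to compound 4 (0.45 log units; beyond the scatter).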

Compound 4, inhibition constant: 6.57 nM
Estimate against measurement, compound 4: 2.3-fold (0.36 log units) above; low and high end bracket the measured number.
By their numbers in this assay, from the lowest: compound 3; then compound 1; then compounds 2 and 4 (each within the scatter of the next).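

In this assay, the amide-type nitrogen takes benzyl in place of the amide hydrogen without a change beyond the scatter (a 1.2-fold higher number from compound 2 to compound 4 (0.09 log units; within the scatter)). For the compounds shown here, the earlier compounds varied only the aryl group on the amine nitrogen, so this is the first sign that a substituent at this nitrogen can leave the number in place, at least alongside the 2-methoxyphenyl group. No available evidence bears on this result.

Going by these compounds, whether benzyl behaves the same alongside the 3-chloro-4-methylphenyl group of compound 3 remains open. So does the outcome for a methyl group, or for a chain ending in an amine or a carboxylic acid, on this nitrogen.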